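The source may hold more compounds than are shown below. What is called first, only, known or untested is meant among the compounds shown, and "the series" means these compounds.

Measured so far:
compound 1, `CN1Cc2cc(-c3ccc(-c4cncc(NS(=O)(=O)c5cccc(C(F)(F)F)c5)c4)s3)cnc2C1=O`: 20300 ug/mL
compound 2, `COc1ncc(-c2ccc(-c3cnc4c(c3)CN(C)C4=O)s2)cc1NS(=O)(=O)c1ccc(F)cc1F`: 18300 ug/mL

For the measured compounds named here, in a physicochemical assay for solubility, read by HPLC (a higher number here means a more soluble compound, a lower number a less soluble compound), compound 2 gives 18300 ug/mL; its only neighbour is compound 1, whose number lies within the scatter of it, so the two read as one level. Compound 3, `CN1Cc2cc(-c3ccc(-c4cncc(NS(=O)(=O)c5ccc(F)cc5F)c4)s3)cnc2C1=O`, is still to be measured in this assay. It differs from compound 2 by hydrogen in place of methoxy on an aromatic carbon. Going by the values given here, no measured pair follows this change, so no step size can be drawn from the data; nothing beyond the scatter is expected in either direction. Compound 3 is therefore expected near compound 2, at an estimated 17000 ug/mL, within 8000 ug/mL to 34000 ug/mL. The expected step from compound 2 to compound 3 is a 1.1-fold lower number from compound 2 to compound 3 (0.03 log units; within the scatter).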

Compound 3, solubility: 20300 ug/mL
The estimate for compound 3 lay 1.2-fold (0.08 log units) below the measured number; low and high end bracket the measured number.
By their numbers in this assay, from the lowest: compounds 2, 1 and 3 (each within the scatter of the next).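

In this assay, hydrogen in place of methoxy on this aromatic carbon leaves the number within the scatter (a 1.1-fold higher number from compound 2 to compound 3 (0.05 log units; within the scatter)), so the methoxy is not needed to hold this level. On the sulfonyl sulfur, 2,4-difluorophenyl in place of 3-(trifluoromethyl)phenyl also gives a step within the scatter (no change at the digits printed from compound 1 to compound 3 (within the scatter)), so neither place has yet moved the number. No measurement offers an explanation for this flat reading. From the compounds shown here alone, whether an amine, a carboxylic acid or a longer alkoxy chain on this aromatic carbon would shift the number stays open. Equally open, going by these compounds, is a saturated amine group on the sulfonyl sulfur.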